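The source may report more compounds than this note shows. Statements on the series, on what has been measured and on what is new or still open speak of the compounds shown alone.

Compound 2 `Cn1c(=O)c(S(=O)(=O)c2ccc(F)cc2F)cc2cnc(Nc3ccncn3)nc21` is the weakest of the three measured compounds in a functional assay on K562 cells (Homo sapiens) for inhibition, read by trypan blue exclusion, with a stated time of 72 h (on this read-out lower numbers stand for stronger inhibition and higher numbers for weaker inhibition), where compound 2 gives 30000 nM. Among the measured compounds shown here, compound 1 `Cn1c(=O)c(S(=O)(=O)c2ccc(Cl)cc2Cl)cc2cnc(Nc3ccc4[nH]ccc4c3)nc21` gives 1000 nM in this assay, and compound 3 `Cn1c(=O)c(S(=O)(=O)c2ccc(Cl)cc2)cc2cnc(Nc3ccc4[nH]ccc4c3)nc21` gives 100 nM; the step of a 10-fold lower number from compound 1 to compound 3 (1.00 log units; beyond the scatter) is the only single-point change among the measured pairs, and it concerns the sulfonyl aryl group rather than the amine. Compound 4 `Cn1c(=O)c(S(=O)(=O)c2ccc(F)cc2F)cc2cnc(Nc3ccc4cc[nH]c4c3)nc21` is the untested compound here; it differs from compound 2 by 1H-indol-6-yl in place of pyrimidin-4-yl on a nitrogen on an aromatic ring.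

For the measured compounds named here, no measured step directly matches this change, since compound 2 differs from both compound 1 and compound 3 at the sulfonyl aryl group as well as at the amine. What the values show is that the two compounds carrying an indole amine, compound 1 and compound 3, both give far lower numbers in this assay than compound 2, which carries the pyrimidinyl amine. On that basis compound 4 is expected to move strongly in the same direction, with an estimated step of a 100-fold lower number from compound 2 to compound 4 (2.00 log units; beyond the scatter). The value of compound 4 in this assay is therefore estimated at 300 nM, with a range from 60 nM to 1500 nM.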

Compound 4, half-maximal inhibitory concentration: 5000 nM
For compound 4 the middle estimate is 17-fold (1.22 log units) below the measured one; the whole stated range lies below it.
By their numbers in this assay, from the lowest: compound 3; then compound 1; then compound 4; then compound 2.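

With the sulfonyl aryl group held constant, the pair of compound 2 and compound 4 isolates the amine substituent in this assay: 1H-indol-6-yl in place of pyrimidin-4-yl on a nitrogen on an aromatic ring gives a 6.0-fold lower number from compound 2 to compound 4 (0.78 log units; beyond the scatter) and so lies beyond the scatter. The earlier compounds offered a single-point reading only at the sulfonyl aryl group, a 10-fold lower number from compound 1 to compound 3 (1.00 log units; beyond the scatter) in that series, so this is the only step shown that shows the amine substituent alone changing the number. Compound 1 and compound 3 differ from compound 4 in more than one place, so their values cannot be set directly against it, and no accompanying measurement explains the step at this position.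

The compounds shown leave open how a plain phenyl group, or a phenyl group carrying a piperazine or a morpholine, would behave on this same nitrogen with the sulfonyl aryl group unchanged. Among the compounds shown here, they also leave open whether swapping pyrimidin-4-yl for 1H-indol-6-yl would give a step of similar size with a different sulfonyl aryl group, such as the one in compound 3.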